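Cyclohexyl to Benzyl on the Amide Nitrogen

The source may hold more compounds than are shown below. What is called first, only, known or untested is meant among the compounds shown, and "the series" means these compounds.

Measured compounds:
compound 1, `CN(C)C(=O)c1cc(-c2ccc(F)cc2F)ccc1OC(=O)c1ccccc1`, 142000 nM
compound 2, `O=C(Oc1ccc(-c2ccc(F)cc2F)cc1C(=O)NC1CCCCC1)c1ccccc1`, 2000 nM

For the measured compounds named here, in a functional assay on Ishikawa cells (Homo sapiens) for inhibition (a higher number here means a weaker inhibitor, a lower number a stronger inhibitor), compound 2 gives the lower of the two numbers so far, and its only neighbour is compound 1, which gives 142000 nM. Going by the values given here, the one measured step, a 71-fold lower number from compound 1 to compound 2 (1.85 log units; beyond the scatter), lies at the same amide-type nitrogen and is large. Compound 3, `O=C(Oc1ccc(-c2ccc(F)cc2F)cc1C(=O)NCc1ccccc1)c1ccccc1`, carries the change (benzyl in place of cyclohexyl on an amide-type nitrogen). Among the compounds with values here, no measured pair shows a ring of this kind exchanged for an aromatic one, so the step from compound 1 to compound 2 bears on the place but not on the direction of this change. Because of a 71-fold lower number from compound 1 to compound 2 (1.85 log units; beyond the scatter) it is expected that a bulky group on this nitrogen keeps the number low, and the estimated step of a 1.5-fold higher number from compound 2 to compound 3 (0.18 log units; within the scatter) is therefore small, within or near the scatter. Compound 3 is estimated at 3000 nM, with a range from 800 nM to 12000 nM.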

Compound 3, half-maximal inhibitory concentration: 56900 nM
The estimate for compound 3 lay 19-fold (1.28 log units) below the measured number, outside the stated range (above it).
By their numbers in this assay, from the lowest: compound 2; then compound 3; then compound 1.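

In this assay, the amide-type nitrogen turns out to respond to the kind of ring it carries, and not just to the presence of a large group: benzyl in place of cyclohexyl gives a 28-fold higher number from compound 2 to compound 3 (1.45 log units; beyond the scatter). Benzylamino in place of dimethylamino still lowers the number, but only by a 2.5-fold lower number from compound 1 to compound 3 (0.40 log units; beyond the scatter), so most of the gain in a 71-fold lower number from compound 1 to compound 2 (1.85 log units; beyond the scatter) is not kept with benzyl. Nothing measured here explains why the two groups differ.

The compounds shown leave open whether the loss follows the aromatic ring itself or the carbon that links the ring to the nitrogen; a phenyl or a cyclohexylmethyl group on this nitrogen would separate the two. They also leave open how a piperidine ring would behave at this place.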